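Methyl for dimethylamino on the benzofuran-bearing core

The source may report more compounds than this note shows. Statements on the series, on what has been measured and on what is new or still open speak of the compounds shown alone.

Compound 2 `CN(C)c1ncnc2c1c(-c1cc3ccccc3o1)cn2[C@@H]1O[C@H](CO)[C@@H](O)[C@H]1O` was tested in a functional assay on K562 cells (Homo sapiens), read by MTT assay, with a stated time of 72 h; on this read-out lower numbers stand for stronger inhibition and higher numbers for weaker inhibition; in this assay compound 2 gives only a limit, > 20000 nM. Compound 1 `Cc1ncnc2c1c(-c1cccs1)cn2[C@@H]1O[C@H](CO)[C@@H](O)[C@H]1O` likewise returns only a limit in this assay, > 20000 nM. Compound 3 `C#Cc1cn([C@@H]2O[C@H](CO)[C@@H](O)[C@H]2O)c2ncnc(N(C)C)c12` gives 110 nM in this assay. Of the three values shown, two sit at the same limit (the limit of > 20000 nM in this assay, at which 2 of the 3 values shown sit), so compound 2 stands among the weakest of the measured set. Going by the values given here, the one measured step, an at least 180-fold lower number from compound 2 to compound 3 (2.25 log units; beyond the scatter), concerns the aryl group and not the substituent changed here.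

Compound 4 `Cc1ncnc2c1c(-c1cc3ccccc3o1)cn2[C@@H]1O[C@H](CO)[C@@H](O)[C@H]1O` differs from compound 2 by methyl in place of dimethylamino on an aromatic carbon. Among the compounds with values here, no measured step in this assay covers this exchange; compound 1 carries the methyl and compound 2 the dimethylamino, but they also differ in the aryl group, and both merely reach the limit. He therefore expects compound 4 to remain at or near the limit, with a step that the limit leaves unreadable from compound 2 to compound 4. His estimate for compound 4 is 30000 nM, between 10000 nM and 100000 nM.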

Compound 4, half-maximal inhibitory concentration: 19500 nM
Estimate against measurement, compound 4: 1.5-fold (0.19 log units) above; the measured number falls inside the stated range.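

Compound 4 is the only compound shown with the 1-benzofuran-2-yl group to return a number rather than a limit in this assay, at 19500 nM. Compound 1 and compound 2 each remain a limit of the assay: the limit of > 20000 nM in this assay, at which 2 of the 4 values shown sit.

Methyl in place of dimethylamino gives an at least 1.0-fold lower number from compound 2 to compound 4 (0.01 log units; that floor lies within the scatter), and 1-benzofuran-2-yl in place of thiophen-2-yl gives an at least 1.0-fold lower number from compound 1 to compound 4 (0.01 log units; that floor lies within the scatter), so each exchange is bounded from one side only and the true size of neither can be read.

The compounds shown leave open how methyl in place of dimethylamino reads on the ethynyl-bearing core of compound 3, which gives 110 nM. They also leave open how a primary amine or a methoxy group would read on this aromatic carbon.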